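Compound 3 to compound 4: an aryl exchange

The compounds below may be only part of what the source reports. "The series", "measured", "known", "first", "only" and "open" are said of these compounds alone.

Measured in a functional assay on MOLT-4 cells (Homo sapiens) for inhibition, read by MTT assay, with a stated time of 72 h; a lower number here means a stronger inhibitor, a higher number a weaker inhibitor:
compound 1 `COc1cc(NC(C)CCCNC(=O)Nc2cccc(Cl)c2)c2ncccc2c1` gives 21000 nM
compound 2 `COc1cc(NC(C)CCCNC(=O)NNC(=O)Nc2ccc(Cl)cc2)c2ncccc2c1` gives 186000 nM
compound 3 `COc1cc(NC(C)CCCNC(=O)NNC(=O)Nc2ccc(Br)cc2)c2ncccc2c1` gives 209000 nM

Compound 3 shares the high end of these numbers with compound 2, the two lying within the scatter of each other, and both stand clearly above compound 1 in this assay.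

The next structure, compound 4 `COc1cc(NC(C)CCCNC(=O)NNC(=O)Nc2cccc(C(F)(F)F)c2)c2ncccc2c1`, has 3-(trifluoromethyl)phenyl in place of 4-bromophenyl on an amide-type nitrogen and is otherwise unchanged.

The closest evidence is a 1.1-fold higher number from compound 2 to compound 3 (0.05 log units; within the scatter), a swap of bromo for chloro on an aromatic carbon that stays within the scatter. The larger steps, an 8.9-fold higher number from compound 1 to compound 2 (0.95 log units; beyond the scatter) and a 10-fold higher number from compound 1 to compound 3 (1.00 log units; beyond the scatter), alter more than the aryl group, so they bear only weakly on this change. Going by the values given here, compound 4 keeps the carbamoyl amino portion of compound 2 and compound 3, while no measured step tests a trifluoromethyl group.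

The expected result is a 1.2-fold lower number from compound 3 to compound 4 (0.09 log units; within the scatter), with no shift beyond the scatter expected. Compound 4 is estimated at 170000 nM, with an expected range of 70000 nM to 350000 nM.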

Compound 4, half-maximal inhibitory concentration: 36000 nM
Compound 4: the middle estimate sits 4.7-fold (0.67 log units) above what was measured, and the stated range ends above it.
By their numbers in this assay, from the lowest: compounds 1 and 4 (each within the scatter of the next); then compounds 2 and 3 (each within the scatter of the next).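

In this assay, the aryl group on the amide-type nitrogen can move the number beyond the scatter while the carbamoyl amino portion stays fixed: 3-(trifluoromethyl)phenyl gives a 5.8-fold lower number from compound 3 to compound 4 (0.76 log units; beyond the scatter) and, against 4-chlorophenyl, a 5.2-fold lower number from compound 2 to compound 4 (0.71 log units; beyond the scatter). The swap of bromo for chloro had shown only a 1.1-fold higher number from compound 2 to compound 3 (0.05 log units; within the scatter), so that halogen exchange gave no sign of this sensitivity. Nothing measured here accounts for the shift.

The exchange alters both the substituent and its numbered place on the phenyl ring in one step, and the compounds shown do not separate the two. Going by these compounds, whether 4-(trifluoromethyl)phenyl, or a phenyl group carrying a nitrile or an amine, follows compound 4 remains open.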